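This account rests on a few compounds, and the source may have more. Where it says the series, first, only, none or still open, it means among the compounds named here.

Measured so far:
compound 1, `Cc1c(Cc2ccccc2)c(=O)oc2cc(OCC(O)CNc3nccs3)ccc12` — 93000 nM
compound 2, `Cc1c(Cc2ccc(C(C)(C)C)cc2)c(=O)oc2cc(OCC(O)CN3CCC(C(N)=O)CC3)ccc12` — 14700 nM

Both were run in an ADME assay on A549 cells (Homo sapiens) for cytotoxicity, read by CellTiter-Glo; a higher number here means that more compound is tolerated, a lower number that less compound is tolerated. Compound 2 gives the lowest of the two numbers; compound 1 gives a higher value, and the gap between the two lies beyond the usual scatter. Within the data shown here, no step between two compounds that differ in one place is available, so the series holds no direct precedent for the change at hand.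

Compound 3, `COc1ccccc1-c1ccc(Cc2c(C)c3ccc(OCC(O)CN4CCC(C(N)=O)CC4)cc3oc2=O)cc1`, is next in line. It differs from compound 2 in one place: 2-methoxyphenyl in place of tert-butyl on an aromatic carbon. Among the measured compounds shown here, with no measured step of comparable kind to lean on, the expectation rests on compound 2 alone, whose 14700 nM sets the anchor. A modest downward shift is expected, close to the edge of the scatter, hence a 1.5-fold lower number from compound 2 to compound 3 (0.17 log units; within the scatter). Compound 3 is therefore estimated at 10000 nM, with a range from 3000 nM to 35000 nM.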

Compound 3, half-maximal cytotoxic concentration: 91600 nM
Estimate against measurement, compound 3: 9.2-fold (0.96 log units) below; the whole stated range lies below it.
By their numbers in this assay, from the lowest: compound 2; then compounds 3 and 1 (each within the scatter of the next).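

The series now holds its first step in one place: in this assay, 2-methoxyphenyl in place of tert-butyl on an aromatic carbon, para to a large group, gives a 6.2-fold higher number from compound 2 to compound 3 (0.79 log units; beyond the scatter). The read-out at this position therefore depends on the group it carries, and here the larger group, with one six-membered aromatic ring and one hydrogen-bond acceptor that tert-butyl lacks, goes with more compound being tolerated. No measurement shown accounts for this rise.

From the compounds shown here alone, a single step cannot separate the added aromatic ring from the methoxy group, so the share of each stays open; an unsubstituted phenyl or a lone methoxy at this position would divide the two. Going by these compounds, whether a hydroxyl or an amine in place of the methoxy would give a similar number also remains open.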